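Expected clearance of compound 4 after adding trifluoromethyl

The source may hold more compounds than are shown below. What is called first, only, known or untested is meant among the compounds shown, and "the series" means these compounds.

Compound 1 `Nc1n[nH]c2cc(-c3ccc(=O)n(Cc4ccccc4)c3)ccc12` was tested in an ADME assay on microsomes (Mus musculus) for metabolic stability, read by LC-MS, using NADPH, with a stated time of 1 h, tested at 1 uM; a lower number here means slower removal, a higher number faster removal of the compound. In that test compound 1 gives < 10 mL.min-1.g-1, which is a limit of the assay rather than a number, so compound 1 sits at the limit of < 10 mL.min-1.g-1 in this assay, at which 1 of the 3 values shown sits. Two further compounds carry a different core: compound 2 `O=c1ccc(-c2ccc3cn[nH]c3c2)cn1Cc1cccc(F)c1` gives 160 mL.min-1.g-1 and compound 3 `O=c1ccc(-c2ccc3cn[nH]c3c2)cn1Cc1ccccc1F` gives 246 mL.min-1.g-1 in this assay. Among the compounds with values here, the only measured step, a 1.5-fold higher number from compound 2 to compound 3 (0.19 log units; within the scatter), exchanges 3-fluorophenyl for 2-fluorophenyl and so does not test a trifluoromethyl entering. Compound 4 `Nc1n[nH]c2cc(-c3ccc(=O)n(Cc4cccc(C(F)(F)F)c4)c3)ccc12` differs from compound 1 by trifluoromethyl in place of hydrogen on an aromatic carbon. Within the data shown here, with no measured step bearing directly on this change, the expectation rests on compound 1 alone. Compound 4 is estimated to give 15 mL.min-1.g-1 (range 5 mL.min-1.g-1 to 60 mL.min-1.g-1), an expected step of an at least 1.5-fold higher number from compound 1 to compound 4 (0.17 log units; that floor lies within the scatter).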

Compound 4, intrinsic clearance in microsomes: < 10 mL.min-1.g-1
Compound 4: a limit, no number; the forecaster's own chance of this, stated with the estimate: 40%; middle value at least 1.5-fold (0.17 log units) away from the limit.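

Compound 1 and compound 4 both give a limit rather than a number in this assay, so no step between them can be read: the limit of < 10 mL.min-1.g-1 in this assay, at which 2 of the 4 values shown sit.

The compounds shown leave open whether trifluoromethyl in place of hydrogen on an aromatic carbon changes intrinsic clearance in microsomes at all.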